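The source may report more compounds than this note shows. Statements on the series, on what has been measured and on what is new or still open speak of the compounds shown alone.

Measured so far in a functional assay on MCF7 cells (Homo sapiens) for cytotoxicity, read by MTT assay, with a stated time of 24 h; on this read-out higher numbers stand for weaker inhibition and lower numbers for stronger inhibition:

Compound 1, `COc1ccc(N2CCN(CCCSc3nc4ccccc4[nH]3)CC2)cc1`, gives 6840 nM.
Compound 2, `Clc1cccc(N2CCN(CCCSc3nc4ccccc4[nH]3)CC2)c1`, gives 54600 nM.
Compound 3, `COc1ccc(N2CCN(CCCSc3nc4cc(Cl)ccc4[nH]3)CC2)cc1`, gives 38500 nM.

Compound 1 and compound 2 share a core and differ at one place: 3-chlorophenyl in place of 4-methoxyphenyl on an amine nitrogen in a ring. This change gives an 8.0-fold higher number from compound 1 to compound 2 (0.90 log units; beyond the scatter). Compound 3 carries the core of compound 1 with one alteration, (chloro in place of hydrogen on an aromatic carbon), and this gives a 5.6-fold higher number from compound 1 to compound 3 (0.75 log units; beyond the scatter). Within the data shown here, compound 2 and compound 3 have no step computed between them; their two values lie within the scatter of each other, so nothing is said about their order.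

Compound 4, `Clc1cccc(N2CCN(CCCSc3nc4cc(Cl)ccc4[nH]3)CC2)c1`, has not yet been measured in this assay. It differs from compound 3 in one place: 3-chlorophenyl in place of 4-methoxyphenyl on an amine nitrogen in a ring. This is the same change that separates compound 1 from compound 2, made here on the core that bears the chloro group described for compound 3. Among the four compounds it occurs twice in all.

Among the measured compounds shown here, the expectation for compound 4 rests on the single precedent. For the measured compounds named here, because an 8.0-fold higher number from compound 1 to compound 2 (0.90 log units; beyond the scatter) was seen on the parent core, the step from compound 3 to compound 4 in this assay is estimated to be of comparable direction and size, a 3.9-fold higher number from compound 3 to compound 4 (0.59 log units; beyond the scatter), though with only one prior instance the size is uncertain and the result may exceed the working range of this assay. Compound 4 is therefore expected to give about 150000 nM, with a plausible range from 50000 nM to 400000 nM.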

Compound 4, half-maximal inhibitory concentration: 61400 nM
Compound 4: the middle estimate sits 2.4-fold (0.39 log units) above what was measured; the range from low to high includes it.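

In this assay, the change from 4-methoxyphenyl to 3-chlorophenyl on an amine nitrogen in a ring does not carry over from one core to the other at the same size: the same change on two cores in this assay, an 8.0-fold higher number (0.90 log units; beyond the scatter) from compound 1 to compound 2 and a 1.6-fold higher number (0.20 log units; within the scatter) from compound 3 to compound 4, 5.0-fold (0.70 log units) apart, beyond the scatter of two such steps The chloro group on the aromatic carbon shows the same dependence on its partner, giving a clear step only where 4-methoxyphenyl is present: the same change on two cores in this assay, a 5.6-fold higher number (0.75 log units; beyond the scatter) from compound 1 to compound 3 and a 1.1-fold higher number (0.05 log units; within the scatter) from compound 2 to compound 4, 5.0-fold (0.70 log units) apart, beyond the scatter of two such steps Read on their own, a 1.6-fold higher number from compound 3 to compound 4 (0.20 log units; within the scatter) and a 1.1-fold higher number from compound 2 to compound 4 (0.05 log units; within the scatter) show that in these four compounds each change registers only when made from compound 1, so the two changes do not add up, but this single set of four compounds gives no cause for that and does not show how either change would behave on any other core.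

The compounds shown leave open how a plain phenyl on the amine nitrogen, a fluoro or methyl group in place of the chloro, or a longer chain would fit this picture. They also leave open whether any such group would give a lower number in this assay than compound 1 gives, 6840 nM.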